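Benzyl in Place of Cyclohexyl: Compound 4 from Compound 1

A few compounds are considered here, and "the series" means these few. Any claim that something is new, unique, unknown or untested is made for them only; others in the source may bear on it.

compound 1 `c1ccc2c(-c3cn4ccnc4c(-c4ccc5ncn(C6CCCCC6)c5c4)n3)cccc2c1` gives 23%
compound 2 `Clc1ccc(-c2cn3ccnc3c(-c3ccc4ncn(C5CCCCC5)c4c3)n2)cc1` gives 36.1%
compound 3 `COc1ccccc1-c1cn2ccnc2c(-c2ccc3ncn(C4CCCCC4)c3c2)n1` gives 24%

Of the compounds shown here, three sharing one core have been measured in a functional assay on UO-31 cells (Homo sapiens) for inhibition, read by sulforhodamine B assay, with a stated time of 48 h, tested at 10 uM; a lower number here means less inhibition, a higher number more inhibition at the concentration tested (going by the name of the read-out). Compound 1 stands lowest of the three numbers, with compound 3 nearest, the step being a number 1 percentage points higher from compound 1 to compound 3 (within the scatter), and compound 2 furthest, the step being a number 13.1 percentage points higher from compound 1 to compound 2 (beyond the scatter). Between compound 2 and compound 3 the step is a number 12.1 percentage points lower from compound 2 to compound 3 (beyond the scatter). All three measured steps exchange the group on an aromatic carbon of the core, and none of them touches the group on the aromatic nitrogen.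

Compound 4 `c1ccc(Cn2cnc3ccc(-c4nc(-c5cccc6ccccc56)cn5ccnc45)cc32)cc1` differs from compound 1 in exactly that other place: benzyl in place of cyclohexyl on an aromatic nitrogen. For the measured compounds named here, no measured step bears on a change at the aromatic nitrogen, so there is nothing here from which a direction could be read. Going by the values given here, the only guidance is that the three measured compounds cluster within a modest span, and compound 1 itself sits at the lower edge of it.

The step from compound 1 to compound 4 is therefore expected to be a number 1 percentage points higher from compound 1 to compound 4 (within the scatter), within the scatter. Compound 4 is estimated to give 24% in this assay, with a range from 8% to 42%.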

Compound 4, a percentage reported as inhibition, at one concentration (the size of the read-out at that concentration, not a potency): 31.3%
The estimate for compound 4 lay 7.3 percentage points below the measured number; the measured number falls inside the stated range.
By their numbers in this assay, from the lowest: compounds 1, 3, 4 and 2 (each within the scatter of the next, the first and the last beyond it).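

In this assay, for the compounds shown here, the exchange of benzyl for cyclohexyl on the aromatic nitrogen gives the first reading at this place, a number 8.3 percentage points higher from compound 1 to compound 4 (within the scatter), so this change, with naphthalen-1-yl held constant on the aromatic carbon, cannot be told apart from repeat measurements. The earlier compounds shown here varied only the group on the aromatic carbon, whereas this result shows that a six-membered aromatic ring of carbon only, reached through the benzyl group, can take the place of the non-aromatic ring of cyclohexyl without a step beyond the scatter at the one concentration tested. Nothing available accounts for the size of this step or for its direction.

The compounds shown leave open whether the same exchange would behave alike with 4-chlorophenyl or 2-methoxyphenyl on the aromatic carbon, since benzyl appears here only with naphthalen-1-yl. They also leave open whether a group of another kind on the aromatic nitrogen, such as a short chain like ethyl, a chain ending in an amine, or a benzyl group carrying a carboxylic acid, would move the number beyond the scatter.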